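A few compounds are considered here, and "the series" means these few. Any claim that something is new, unique, unknown or untested is made for them only; others in the source may bear on it.

Compound 1 `CC(=O)N1CC(CC#N)(n2cc(-c3nc(-c4cnn(C)c4)cn4nccc34)cn2)C1` gives < 8 uL/min in an ADME assay on microsomes from liver (Homo sapiens) for pharmacokinetics (on this read-out lower numbers stand for slow clearance and higher numbers for fast clearance), which is a limit of the assay.
Compound 2 `CCN1CC(CC#N)(n2cc(-c3nc(-c4cnn(C)c4)cn4nccc34)cn2)C1` gives 21 uL/min.
Compound 3 `Cn1ccc(-c2cn3nccc3c(-c3cnn([C@]4(CC#N)C[C@@H](C#N)C4)c3)n2)n1` gives < 8 uL/min, again a limit of the assay rather than a number.

Compound 3 therefore sits at the floor of what this assay reports, as does compound 1: the limit of < 8 uL/min in this assay, at which 2 of the 3 values shown sit. Compound 4 `Cn1ccc(-c2cn3nccc3c(-c3cnn([C@]4(CC#N)C[C@H](C#N)C4)c3)n2)n1` has the same atoms and bonds as compound 3 and differs only in configuration: the two compounds have the same atoms and bonds and differ only in configuration as drawn: 2 of 2 stereo elements differ (all stereocentres are inverted: mirror images); a stereocentre at a saturated ring carbon is drawn r in compound 3 and s in compound 4; a stereocentre at a saturated ring carbon is drawn r in compound 3 and s in compound 4. For the measured compounds named here, the one measured step, an at least 2.6-fold higher number from compound 1 to compound 2 (0.41 log units; beyond the scatter), concerns a different change, ethyl in place of acetyl on an amine nitrogen in a ring, and so says nothing about inverting stereocentres. Going by the values given here, no measured pair here shows what a mirror image does. For compound 4 a step that the limit leaves unreadable from compound 3 to compound 4 is expected, nothing beyond the scatter. Compound 4 is estimated at 7 uL/min, between 4 uL/min and 14 uL/min, most likely reported again only as a limit.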

Compound 4, intrinsic clearance in a liver preparation (reported as CLH), per the amount of preparation that the assay uses: 23 uL/min
Compound 4: middle estimate off by 3.3-fold (0.52 log units), on the low side; the whole stated range lies below it.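

In this assay, inverting the two stereocentres at saturated ring carbons gives an at least 2.8-fold higher number from compound 3 to compound 4 (0.45 log units; beyond the scatter). For the compounds shown here, this is the first sign here that configuration alone can move this read-out, whereas the earlier step exchanged one group for another on a ring nitrogen. No other structural change accompanies this step: the fact that compounds 3 and 4 differ only in the configuration as drawn

Going by these compounds, the value of compound 3 is a limit of the assay, so the full size of the step stays open. On these data alone, whether a carboxylic acid in place of the nitrile on the saturated ring would show the same dependence on configuration also remains open.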